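This account rests on a few compounds, and the source may have more. Where it says the series, first, only, none or still open, it means among the compounds named here.

Measured compounds, all in an ADME assay on C8166 cells (Homo sapiens) for cytotoxicity, read by MTT assay; on this read-out higher numbers stand for lower toxicity in this test and lower numbers for higher toxicity in this test:

compound 1 `Cc1cc(S(N)(=O)=O)ccc1NC(=O)COc1ccc(Cl)cc1Oc1ccc2ccccc2c1`: 119000 nM
compound 2 `Cc1cc(S(N)(=O)=O)ccc1NC(=O)COc1ccc(Cl)cc1Oc1ccc2ccccc2c1Cl`: 40700 nM
compound 3 `Cc1cc(S(N)(=O)=O)ccc1NC(=O)COc1ccc(F)cc1Oc1cc2ccccc2cc1C`: 66900 nM

Compound 3 sits among these three numbers without standing apart: its value lies within the usual scatter of both compound 1 and compound 2, so no ranking among the three is claimed. Among the compounds with values here, the only change between measured compounds that is a clean single-point step is a 2.9-fold lower number from compound 1 to compound 2 (0.47 log units; beyond the scatter), a modest move to a lower number on adding a chloro group to an aromatic carbon.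

Compound 4 `Cc1cc(S(N)(=O)=O)ccc1NC(=O)COc1ccc(Cl)cc1Oc1cc2ccccc2cc1C` differs from compound 3 by chloro in place of fluoro on an aromatic carbon. Within the data shown here, no measured pair shows this exact swap of fluoro for chloro; the nearest comparison is the chloro-for-hydrogen step from compound 1 to compound 2, which bears on it only loosely, since the group leaving in compound 3 is itself a halogen. A step in compound 4 is therefore expected to be smaller than that one, most likely toward a lower number in this assay but not clearly beyond the scatter.

For compound 4 the value in this assay is estimated at 50000 nM, with a range of 25000 nM to 100000 nM, which means an expected step of a 1.3-fold lower number from compound 3 to compound 4 (0.13 log units; within the scatter).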

Compound 4, half-maximal cytotoxic concentration: 76700 nM
Beside the measured number, compound 4's estimate is 1.5-fold (0.19 log units) below it; low and high end bracket the measured number.
By their numbers in this assay, from the lowest: compounds 2, 3, 4 and 1 (each within the scatter of the next, the first and the last beyond it).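

Notes on the halogen position, in this assay: on this aromatic carbon, meta to a large group and para to a large group, chloro in place of fluoro gives a 1.1-fold higher number from compound 3 to compound 4 (0.06 log units; within the scatter), so the two halogens are not told apart here with the 3-methylnaphthalen-2-yl group on the oxygen. Within the data shown here, compound 4 also links the earlier compounds through two single changes: the added methyl group gives a 1.6-fold lower number from compound 1 to compound 4 (0.19 log units; within the scatter), and 3-methylnaphthalen-2-yl in place of 1-chloronaphthalen-2-yl on an oxygen on an aromatic ring gives a 1.9-fold higher number from compound 2 to compound 4 (0.28 log units; within the scatter), so neither step separates compound 4 from its partner, unlike the chloro-for-hydrogen step, a 2.9-fold lower number from compound 1 to compound 2 (0.47 log units; beyond the scatter). No available evidence bears on the reasons for these results.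

Still open, from the compounds shown here alone, is whether hydrogen, a methoxy group or a nitrile at this same position would remain within the scatter of the two halogens. Going by these compounds, it is also open whether the fluoro-to-chloro swap would stay as small with 1-chloronaphthalen-2-yl on the oxygen.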